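Cyano for cyclopropylsulfonyl: from compound 3 to compound 4

This account rests on a few compounds, and the source may have more. Where it says the series, first, only, none or still open, it means among the compounds named here.

In a physicochemical assay for solubility, read by HPLC, using the shake flask method, in phosphate buffer, with a stated time of 2 h, at pH 6.5 (a lower number here means a less soluble compound, a higher number a more soluble compound), compound 3 `Nc1ccc(-c2nc(-c3ccc(S(=O)(=O)C4CC4)cc3)cnc2N)cn1` reads 13000 nM and is the lower of the two true numbers in the series. Compound 1 `Nc1ncc(-c2ccc(C(=O)N3CC(O)C3)cc2)nc1-c1ccc(C(F)(F)F)cc1` reads 55000 nM on the same read-out, and that number stands higher, beyond the scatter. Compound 2 `NC(=O)c1ccc(-c2cnc(N)c(-c3ccc(C(F)(F)F)cc3)n2)cc1` returns < 5000 nM as a limit and not a number.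

Next comes compound 4 `N#Cc1ccc(-c2cnc(N)c(-c3ccc(N)nc3)n2)cc1`, with cyano in place of cyclopropylsulfonyl on an aromatic carbon, para to a large group cyano in place of cyclopropylsulfonyl on an aromatic carbon as the counted change from compound 3. Going by the values given here, no measured step makes this same change. The nearest guide is an at least 11-fold lower number from compound 1 to compound 2 (1.04 log units; beyond the scatter) with amino in place of 3-hydroxyazetidin-1-yl on a carbonyl carbon, a large step beyond the scatter that ends at a limit. There too a ring-bearing group gives way to a ring-free one, but it sits elsewhere and is a single pair, so it suggests a direction only. A moderate fall is therefore expected, smaller than that step, and the reading could land on the limit of < 5000 nM in this assay, at which 1 of the 3 values shown sits, and give no number. The expected move is a 2.0-fold lower number from compound 3 to compound 4 (0.30 log units; within the scatter) on this thin basis. Compound 4 is estimated at 6500 nM (expected range 2500 nM to 18000 nM) in this assay for now.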

Compound 4, solubility: < 5000 nM
Compound 4: no number, only a limit (the forecaster's own chance of this, stated with the estimate: 40%); middle value at least 1.3-fold (0.11 log units) from the limit.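

In this assay, the aromatic carbon para to a large group now has a measured step of its own: cyano in place of cyclopropylsulfonyl gives an at least 2.6-fold lower number from compound 3 to compound 4 (0.41 log units; beyond the scatter), so the swap of a ring-bearing group for a ring-free one registers at this position as well as on the carbonyl carbon. Compound 4 gives < 5000 nM, which is a limit and not a number, so the step has a lower bound on its size and no exact size. Set beside an at least 11-fold lower number from compound 1 to compound 2 (1.04 log units; beyond the scatter), it makes two steps in which a ring-bearing group leaves, a ring-free one enters and the reading ends at a limit, with no step shown going against this, although the two changes sit in different places and the series now leans heavily on that limit: the limit of < 5000 nM in this assay, at which 2 of the 4 values shown sit.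

Going by these compounds, how far the reading falls at this position stays open, and so does whether the loss follows the ring, the count of heavy atoms or the nitrile itself. A carboxylic acid, an amine or a longer chain on this same aromatic carbon would test whether any ring-free group can hold a true number in this assay.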